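The source may hold more compounds than are shown below. What is called first, only, known or untested is meant among the compounds shown, and "the series" means these compounds.

Compound 1 `Nc1scc(CN2CCN(c3ccc(Cl)cc3Cl)CC2)c1C(=O)c1ccc(Cl)cc1`: in an assay on CHO cells for displacement of a labelled ligand from adenosine receptor A3 (Homo sapiens), read by scintillation counting, with a stated time of 120 min, tested at 10 uM (on this read-out higher numbers stand for more inhibition at the one concentration tested (going by the name of the read-out) and lower numbers for less inhibition), compound 1 gives 0%.
Compound 2 `Nc1scc(CN2CCN(c3cc(Cl)cc(Cl)c3)CC2)c1C(=O)c1ccc(Cl)cc1`: in this assay compound 2 gives 1%.

Compound 1 stands at the bottom of the two numbers shown, with compound 2 as its only neighbour; the step of a number 1 percentage points higher from compound 1 to compound 2 (within the scatter) lies within the scatter, so the two cannot be told apart. The unmeasured compound 3 `Nc1scc(CN2CCN(c3ccc([N+](=O)[O-])cc3)CC2)c1C(=O)c1ccc(Cl)cc1` differs from compound 1 in one place: 4-nitrophenyl in place of 2,4-dichlorophenyl on an amine nitrogen in a ring. Going by the values given here, the one measured step also exchanges the group on that ring nitrogen, and it brought no change beyond the scatter. Nothing measured here points to a larger shift from a 4-nitrophenyl group, so the step expected in this assay is none beyond the scatter. Compound 3 is therefore estimated at 3%, between -8% and 15%. The expected step is a number 3 percentage points higher from compound 1 to compound 3 (within the scatter).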

Compound 3, a percentage reported as inhibition, at one concentration (the size of the read-out at that concentration, not a potency): 2%
Estimate against measurement, compound 3: 1 percentage points above; the measured number falls inside the stated range.
By their numbers in this assay, from the lowest: compounds 1, 2 and 3 (each within the scatter of the next).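

The earlier pair only moved two chlorines around the phenyl ring on the amine nitrogen, whereas compound 3 removes both chlorines and places a 4-nitrophenyl group there, bringing 2 hydrogen-bond acceptors to a group that had none. In this assay, this larger exchange gives a number 2 percentage points higher from compound 1 to compound 3 (within the scatter) and a number 1 percentage points higher from compound 2 to compound 3 (within the scatter), so this position shows no readable difference across three differently substituted phenyl rings, all with numbers close to nothing at the one concentration tested. No measurement is at hand that would explain this result.

Still open, as far as these compounds go, is whether an amine or a carboxylic acid on that phenyl ring, or a longer alkyl chain in place of the ring on the nitrogen, would lift the number beyond the scatter. The compounds shown also leave open whether any change to the 4-chlorophenyl group on the carbonyl would do so.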